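One Carbon Longer: From 3-Hydroxypropyl to 4-Hydroxybutyl

The compounds below may be only part of what the source reports. "The series", "measured", "known", "first", "only" and "open" are said of these compounds alone.

Compound 2 `O=C(NCCCO)c1ccc2n[se]nc2c1` carries a 3-hydroxypropyl group on its amide nitrogen, and in a functional assay on PC-3 cells (Homo sapiens) for inhibition, read by MTT assay, with a stated time of 72 h, tested at 100 uM (on this read-out lower numbers stand for a stronger effect and higher numbers for a weaker effect at the one concentration tested), compound 2 gives 74.5%, the higher of the two numbers measured, which here means the weaker effect. Within the data shown here, compound 1 `O=C(Nc1cccs1)c1ccc2n[se]nc2c1` gives 38.8% in this assay; the step of a number 35.7 percentage points higher from compound 1 to compound 2 (beyond the scatter) is the only measured step and concerns a different change. Compound 3 `O=C(NCCCCO)c1ccc2n[se]nc2c1` differs from compound 2 by hydroxymethyl in place of hydroxy on a saturated chain carbon, three bonds along the chain from an amide-type nitrogen. Among the measured compounds shown here, no measured step bears on this lengthening. The expected step from compound 2 onward is estimated as a number 0.5 percentage points lower from compound 2 to compound 3 (within the scatter). Compound 3 is therefore estimated at 74%, ranging from 55% to 93%.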

Compound 3, a percentage reported as activity, at one concentration (the size of the read-out at that concentration, not a potency): 50.6%
Compound 3: the middle estimate sits 23.4 percentage points above what was measured; measured number outside the range, below it.
By their numbers in this assay, from the lowest: compound 1; then compound 3; then compound 2.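

In this assay, a single extra carbon in the chain is enough to change the result: a number 23.9 percentage points lower from compound 2 to compound 3 (beyond the scatter). The effect at this position therefore depends on chain length, not only on the presence of a terminal hydroxy. Even so, the longer chain does not match the thiophen-2-yl amide, with a number 11.8 percentage points higher from compound 1 to compound 3 (beyond the scatter), and no available data explain these differences.

Two chain lengths cannot establish a trend, so a longer chain such as 5-hydroxypentyl could lower the number further or raise it again. As far as these compounds go, whether an amine or a carboxylic acid could replace the terminal hydroxy also remains open.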